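Amide-nitrogen aryl series: methylphenyl to fluoropyrimidinyl

The source may hold more compounds than are shown below. What is called first, only, known or untested is meant among the compounds shown, and "the series" means these compounds.

Three measured members of the series share one core and differ only in the aromatic group on the amide-type nitrogen in the ring. In a functional assay on HEK293 cells for positive allosteric modulation of metabotropic glutamate receptor 5 (Homo sapiens), read by calcium flux (on this read-out higher numbers stand for larger maximal responses and lower numbers for smaller maximal responses), compound 1 `O=C1c2cc(COc3ccccc3)nn2CCN1c1ccc(F)cc1` gives 79%, compound 2 `O=C1c2cc(COc3ccccc3)nn2CCN1c1ccc(F)c(F)c1` gives 81% and compound 3 `Cc1ccc(N2CCn3nc(COc4ccccc4)cc3C2=O)cc1` gives 65%. Compound 3 stands lowest of the three numbers; its gap to compound 1 and its gap to compound 2 each lie beyond the scatter, whereas compound 1 and compound 2 are within the scatter of each other, as a number 2 percentage points higher from compound 1 to compound 2 (within the scatter) shows.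

Compound 4 `O=C1c2cc(COc3ccccc3)nn2CCN1c1ncc(F)cn1` has not yet been measured in this assay. Its change from compound 3 is 5-fluoropyrimidin-2-yl in place of 4-methylphenyl on an amide-type nitrogen in a ring. Among the compounds with values here, two measured steps bear on this: a number 14 percentage points lower from compound 1 to compound 3 (beyond the scatter) and a number 16 percentage points lower from compound 2 to compound 3 (beyond the scatter), both modest and both beyond the scatter, place the 4-methylphenyl member below the two fluoro-bearing members. Within the data shown here, compound 4 likewise leaves the 4-methylphenyl behind and brings a fluorine-bearing ring, but a ring with two hetero atoms has no precedent among the measured compounds, so the expectation carries extra uncertainty. A modest upward step a number 10 percentage points higher from compound 3 to compound 4 (within the scatter) is therefore expected in this assay. Compound 4 is estimated to reach 75%, with a range from 58% to 90%.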

Compound 4, largest response reached (Emax), in percent of the reference or control that the assay uses: 72%
Compound 4: middle estimate off by 3 percentage points, on the high side; measured number inside the range.
By their numbers in this assay, from the lowest: compounds 3, 4, 1 and 2 (each within the scatter of the next, the first and the last beyond it).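

In this assay, the amide-type nitrogen in a ring holds a six-membered aromatic ring with 2 hetero atoms, the first such ring in the series, and the maximal response of compound 4 cannot be separated from that of any other compound shown: a number 7 percentage points higher from compound 3 to compound 4 (within the scatter) and a number 7 percentage points lower from compound 1 to compound 4 (within the scatter) and a number 9 percentage points lower from compound 2 to compound 4 (within the scatter) all stand within the scatter. The gap that sets compound 3 apart from compound 1 and compound 2 therefore leaves compound 4 unassigned to either side, even though 5-fluoropyrimidin-2-yl brings hydrogen-bond acceptors that 4-methylphenyl lacks and the two groups have the same heavy-atom count. No independent data bear on why the response of this ring falls where it does.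

Still open, from the compounds shown here alone, is whether the fluorine or the ring nitrogens account for the reading, a question that pyrimidin-2-yl without fluorine, 5-fluoropyridin-2-yl or 5-methylpyrimidin-2-yl on the same nitrogen would address. Open too is how a saturated group such as cyclohexyl or morpholine would read at this place: every compound shown carries an aromatic ring there.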